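A few compounds are considered here, and "the series" means these few. Any claim that something is new, unique, unknown or untested is made for them only; others in the source may bear on it.

Compound 1 `CCc1cnc(N2CCC(c3coc4c(N5CCc6cc(S(C)(=O)=O)ccc65)ncnc34)CC2)nc1`: 154%
Compound 2 `CS(=O)(=O)c1ccc2c(c1)CCN2c1ncnc2c(C3CCN(c4ncccn4)CC3)coc12`: 196%
Compound 3 `CC(C)(C)OC(=O)N1CCC(c2coc3c(N4CCc5cc(S(C)(=O)=O)ccc54)ncnc23)CC1`: 123%

In a functional assay on cells for agonist activity at Glucose-dependent insulinotropic receptor (Homo sapiens), read by a luciferase reporter, with a stated time of 4 h (a higher number here means a larger maximal response, a lower number a smaller maximal response), compound 3 stands lowest of the three measured compounds. Its distance from the others is told by a number 31 percentage points lower from compound 1 to compound 3 (beyond the scatter) and a number 73 percentage points lower from compound 2 to compound 3 (beyond the scatter), both beyond the scatter. Compound 4 `CS(=O)(=O)c1ccc2c(c1)CCN2c1ncnc2c(C3CCN(c4ncc(O)cn4)CC3)coc12` differs from compound 3 in one place: 5-hydroxypyrimidin-2-yl in place of tert-butoxycarbonyl on an amine nitrogen in a ring. Both measured steps bear on this change, since each replaced a pyrimidin-2-yl on that ring nitrogen with tert-butoxycarbonyl and lowered the maximal response, by a large margin in each case. Putting a pyrimidin-2-yl back, here one carrying a hydroxy group, is therefore expected to raise the maximal response beyond the scatter. For compound 4 the expected value is 170%, within a range of 135% to 205%, which means an expected step of a number 47 percentage points higher from compound 3 to compound 4 (beyond the scatter).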

Compound 4, largest response reached (Emax), in percent of the reference or control that the assay uses: 145%
Estimate against measurement, compound 4: 25 percentage points above, within the range that was stated.
By their numbers in this assay, from the lowest: compound 3; then compounds 4 and 1 (each within the scatter of the next); then compound 2.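

In this assay, the 5-hydroxypyrimidin-2-yl group on the ring nitrogen still beats tert-butoxycarbonyl, but only modestly (a number 22 percentage points higher from compound 3 to compound 4 (beyond the scatter)). On the aromatic carbon of that group, hydroxy falls clearly short of hydrogen (a number 51 percentage points lower from compound 2 to compound 4 (beyond the scatter)) yet cannot be told apart from ethyl (a number 9 percentage points lower from compound 1 to compound 4 (within the scatter)), so both of these groups give a smaller maximal response than hydrogen does. No measurement shown explains this drop. Going by these compounds, whether a methoxy group, an amine or a carboxylic acid on that carbon would also fall short of hydrogen remains open.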